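Pyrimidine for pyridine on a piperazine sulfonamide

The source may hold more compounds than are shown below. What is called first, only, known or untested is meant among the compounds shown, and "the series" means these compounds.

Compounds measured in a functional assay on CHO-K1 cells for antagonist activity at C-X-C chemokine receptor type 3 (Homo sapiens), read by FLIPR and calcium flux; on this read-out higher numbers stand for weaker inhibition and lower numbers for stronger inhibition:
compound 1 `CC1(C)[C@@H]2CC[C@@]1(CS(=O)(=O)N1CCN(c3cc(C(F)(F)F)ccn3)CC1)C(=O)C2` gives 25100 nM
compound 2 `CC1CN(c2ccc(C(F)(F)F)cn2)CCN1S(=O)(=O)C[C@]12CC[C@H](CC1=O)C2(C)C` gives 631 nM
compound 3 `CC1(C)[C@@H]2CC[C@@]1(CS(=O)(=O)N1CCN(c3nc(Cl)c(C(F)(F)F)cc3Cl)CC1)C(=O)C2` gives 316 nM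

Of the three, compound 1 stands highest: in this assay compound 1 gives the weakest inhibition, with both compound 2 and compound 3 reaching clearly lower values, and each gap to compound 1 lies beyond the scatter of repeated measurements. Compound 4 `CC1(C)[C@@H]2CC[C@@]1(CS(=O)(=O)N1CCN(c3ncc(C(F)(F)F)cn3)CC1)C(=O)C2` has not yet been measured. It keeps the shared core of compound 1 and differs only in the aryl group on the ring amine nitrogen: 5-(trifluoromethyl)pyrimidin-2-yl in place of 4-(trifluoromethyl)pyridin-2-yl on an amine nitrogen in a ring. Among the measured compounds shown here, no measured pair isolates this exact change, so the size of the step can only be guessed. Since compound 1 sits so far above the other two, a move toward lower numbers is thought more likely than the reverse, but the step is expected to be modest, and a value within the scatter of compound 1 cannot be excluded. Compound 4 is therefore estimated at 10000 nM, within a range of 2000 nM to 40000 nM, which corresponds to an expected step of a 2.5-fold lower number from compound 1 to compound 4 (0.40 log units; beyond the scatter).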

Compound 4, half-maximal inhibitory concentration: 316 nM
For compound 4 the middle estimate is 32-fold (1.50 log units) above the measured one; the measured number lies below the stated range.
By their numbers in this assay, from the lowest: compounds 3, 4 and 2 (each within the scatter of the next); then compound 1.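

In this assay the aryl group on the ring amine nitrogen proves to be a place where a single exchange has a large effect: 5-(trifluoromethyl)pyrimidin-2-yl in place of 4-(trifluoromethyl)pyridin-2-yl gives a 79-fold lower number from compound 1 to compound 4 (1.90 log units; beyond the scatter) with the shared core untouched. Among the compounds shown here, the earlier compounds held no pair differing only here, so this is the first direct reading of a step at this position. The exchange alters both the number of ring hetero atoms and the place of the trifluoromethyl group, and nothing measured here accounts for the size of the step.

Going by these compounds, whether the added ring nitrogen or the moved trifluoromethyl group carries the step remains open. So does whether a nitrile or a methoxy group could replace trifluoromethyl on the pyrimidine ring.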